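This account rests on a few compounds, and the source may have more. Where it says the series, first, only, none or still open, it means among the compounds named here.

Compound 1 `Nc1ccccc1NC(=O)c1ccc(CNCc2nc(-c3ccc(F)cc3)no2)cc1` is the point of reference in this set. In a functional assay on A549 cells (Homo sapiens) for inhibition, read by MTT assay, with a stated time of 72 h (on this read-out higher numbers stand for weaker inhibition and lower numbers for stronger inhibition), compound 1 gives 10700 nM. Compound 2 `Nc1ccccc1NC(=O)c1ccc(CNCc2nc(-c3cccs3)no2)cc1` differs from it by thiophen-2-yl in place of 4-fluorophenyl on an aromatic carbon. In this assay compound 2 reaches only the limit of the measurement, > 100000 nM. The change brought an at least 9.3-fold higher number from compound 1 to compound 2 (0.97 log units; beyond the scatter). Compound 3 `O=C(NO)c1ccc(CNCc2nc(-c3ccc(F)cc3)no2)cc1` carries a different core, the difference being (hydroxy in place of 2-aminophenyl on an amide-type nitrogen). In this assay compound 3 likewise reaches only the limit, > 100000 nM. That difference in the cores brought an at least 9.3-fold higher number from compound 1 to compound 3 (0.97 log units; beyond the scatter). Compound 4 `O=C(NO)c1ccc(CNCc2nc(-c3cccs3)no2)cc1` remains to be measured in this assay. It differs from compound 3 by thiophen-2-yl in place of 4-fluorophenyl on an aromatic carbon, the same change that was made from compound 1 to compound 2. The expectation for compound 4 rests on two things: compound 3 already sits at the limit, > 100000 nM, and the earlier step, an at least 9.3-fold higher number from compound 1 to compound 2 (0.97 log units; beyond the scatter), made the number higher rather than lower, so that the limit of > 100000 nM in this assay, at which 2 of the 3 values shown sit, is where compound 4 is expected to end up as well. Compound 4 is therefore expected to give about 250000 nM, with a likely range from 100000 nM to 1000000 nM. For compound 4 this means an expected step that the limit leaves unreadable from compound 3 to compound 4.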

Compound 4, half-maximal inhibitory concentration: > 100000 nM
Compound 4 ended at the assay's limit; the forecaster's own chance of this, stated with the estimate: 92%; the middle value does not contradict the limit.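

In this assay compound 4 gives > 100000 nM, which is a limit of the assay. Compound 2 and compound 3 also sit at a limit, so neither step to compound 4, from compound 3 or from compound 2, can be read. The compounds shown leave open how compound 2, compound 3 and compound 4 differ from one another.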